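The source may report more compounds than this note shows. Statements on the series, on what has been measured and on what is new or still open speak of the compounds shown alone.

In a functional assay on NCI-H460 cells (Homo sapiens) for cytotoxicity, read by MTT assay, with a stated time of 72 h (a lower number here means a stronger inhibitor, a higher number a weaker inhibitor), compound 1 (`CC1CCN(Cc2ccc3nc(NC(=O)N/N=C/c4cn(Cc5ccc(Cl)cc5Cl)c5ccccc45)sc3c2)CC1`) gives 1660 nM and compound 2 (`CC1CCN(Cc2ccc3nc(NC(=O)N/N=C/c4cn(Cc5ccccc5Cl)c5ccccc45)sc3c2)CC1`) gives 1080 nM and the two lie within the scatter of each other. Neither can yet be called the better one. Compound 3 (`CC1CCN(Cc2ccc3nc(NC(=O)N/N=C/c4cn(Cc5ccccc5)c5ccccc45)sc3c2)CC1`) differs from compound 2 by a single change (hydrogen in place of chloro on an aromatic carbon) in which hydrogen takes the place of chloro on an aromatic carbon, so 2-chlorobenzyl becomes benzyl. Within the data shown here, the only measured step of this kind removed a different chlorine (a 1.5-fold lower number from compound 1 to compound 2 (0.19 log units; within the scatter)) and it is small. Among the measured compounds shown here, no measurement yet shows what removing this last chlorine does, so that step is only a loose guide. The expected outcome in this assay is no shift beyond the scatter, with an estimated step (a 1.1-fold lower number from compound 2 to compound 3 (0.03 log units; within the scatter)) of no clear direction. Compound 3 is estimated at 1000 nM (expected range 450 nM to 2300 nM) in this measurement.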

Compound 3, half-maximal inhibitory concentration: 1910 nM
Beside the measured number, compound 3's estimate is 1.9-fold (0.28 log units) below it; the range from low to high includes it.
By their numbers in this assay, from the lowest: compounds 2, 1 and 3 (each within the scatter of the next).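

In this assay, replacing the 2-chlorobenzyl group with plain benzyl gives a 1.8-fold higher number from compound 2 to compound 3 (0.25 log units; within the scatter), so the chlorine on this aromatic carbon, ortho to a large group, is not shown to matter here. Going directly from the 2,4-dichlorophenyl group to phenyl, with both chlorines replaced by hydrogen, gives a 1.2-fold higher number from compound 1 to compound 3 (0.06 log units; within the scatter), which also stays within the scatter. Across compound 1, compound 2 and compound 3, then, a benzyl ring carrying two chlorines, one chlorine or none cannot be told apart, and chlorine is not shown to be needed for this cytotoxicity.

Going by these compounds, whether a different kind of group on this ring, such as a methoxy group, an amine or a carboxylic acid, would move the number beyond the scatter remains open. Nothing available explains why these three compounds give the numbers they do.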